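The compounds below may be only part of what the source reports. "The series", "measured", "known", "first", "only" and "open" are said of these compounds alone.

Measured in an ADME assay (liver) for metabolic stability, with Liver microsome (Homo sapiens) as the target, using microsomes and NADPH, with a stated time of 30 min, tested at 1 uM; a higher number here means faster removal of the compound, a lower number slower removal:
- compound 1 `Cn1cc(-c2cc(C(O)(C(F)(F)F)C(F)(F)F)cnc2N2CCN(S(=O)(=O)c3ccc(N)nc3)CC2)cn1`: 19 mL.min-1.g-1
- compound 2 `Nc1ccc(S(=O)(=O)N2CCN(c3ncc(C(O)(C(F)(F)F)C(F)(F)F)cc3-c3cnccc3F)CC2)cn1`: 17 mL.min-1.g-1
- compound 3 `Cc1ccc(-c2cc(C(O)(C(F)(F)F)C(F)(F)F)cnc2N2CCN(S(=O)(=O)c3ccc(N)nc3)CC2)cn1`: 43 mL.min-1.g-1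

Compound 3 gives the highest number of the three, with a 2.3-fold higher number from compound 1 to compound 3 (0.35 log units; beyond the scatter) and a 2.5-fold higher number from compound 2 to compound 3 (0.40 log units; beyond the scatter). The remaining pair shows a 1.1-fold lower number from compound 1 to compound 2 (0.05 log units; within the scatter).

Compound 4 `Nc1ccc(S(=O)(=O)N2CCN(c3ncc(C(O)(C(F)(F)F)C(F)(F)F)cc3-c3ccc4sccc4c3)CC2)cn1` has 1-benzothiophen-5-yl in place of 6-methylpyridin-3-yl on an aromatic carbon.

All three measured steps exchange a group on an aromatic carbon, so they are the nearest guide, but none of them brings in 1-benzothiophen-5-yl. The largest of them, a 2.5-fold higher number from compound 2 to compound 3 (0.40 log units; beyond the scatter), is modest, and a step of about that size or smaller is expected in this assay. The direction rests on judgement alone, and a higher number is the working expectation, though a lower one cannot be excluded. The estimated step is a 1.4-fold higher number from compound 3 to compound 4 (0.14 log units; within the scatter). The expected value for compound 4 is 60 mL.min-1.g-1, with an estimated range of 25 mL.min-1.g-1 to 130 mL.min-1.g-1.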

Compound 4, intrinsic clearance in microsomes: 48 mL.min-1.g-1
For compound 4 the middle estimate is 1.3-fold (0.10 log units) above the measured one; the range from low to high includes it.
By their numbers in this assay, from the lowest: compounds 2 and 1 (each within the scatter of the next); then compounds 3 and 4 (each within the scatter of the next).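

In this assay, 1-benzothiophen-5-yl and 6-methylpyridin-3-yl cannot be told apart at this position, on an aromatic carbon ortho to a large group (a 1.1-fold higher number from compound 3 to compound 4 (0.05 log units; within the scatter)). A group with no ring nitrogen, made of a five-membered aromatic ring and a six-membered aromatic ring of carbon only, therefore reads the same here as compound 3. Both a 2.8-fold higher number from compound 2 to compound 4 (0.45 log units; beyond the scatter) and a 2.5-fold higher number from compound 1 to compound 4 (0.40 log units; beyond the scatter) lie beyond the scatter, which places compound 3 and compound 4 together as an upper pair over compound 1 and compound 2. Nothing measured here explains this grouping.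

Open, on these data alone, is whether an amine, a carboxylic acid or a saturated ring at this position would move the number outside the span of these four compounds. The compounds shown also leave open whether the same grouping holds with any change to the shared core.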